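Swapping a Methoxy for a Hydroxy on Compound 2

The compounds below may be only part of what the source reports. "The series", "measured", "known", "first", "only" and "open" are said of these compounds alone.

In a functional assay on A549 cells (Homo sapiens) for antiproliferative activity, read by MTT assay, with a stated time of 48 h (a lower number here means a stronger inhibitor of growth, a higher number a weaker inhibitor of growth), compound 1 `COC(=O)N1N=C(c2cccc(OC)c2)CC1c1cc(OC)c(OC)c(OC)c1` gives 2590 nM and compound 2 `CCOC(=O)N1N=C(c2cccc(OC)c2)CC1c1cc(OC)c(OC)c(OC)c1` gives 5920 nM, the higher of these two measured numbers. Compound 3 `COc1cccc(C2=NN(C(=O)OCc3ccccc3)C(c3cc(OC)c(OC)c(OC)c3)C2)c1` reads > 10000 nM, which is a limit of the assay and not a number.

Compound 4 `CCOC(=O)N1N=C(c2cccc(O)c2)CC1c1cc(OC)c(OC)c(OC)c1` differs from compound 2 in one place: hydrogen in place of methyl on an oxygen on an aromatic ring. This puts hydrogen in place of methyl on an oxygen on an aromatic ring, turning 3-methoxyphenyl into 3-hydroxyphenyl.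

Among the compounds with values here, no measured step touches that place. All three concern the saturated chain carbon bound to an oxygen next to a carbonyl group. The first is a 2.3-fold higher number from compound 1 to compound 2 (0.36 log units; beyond the scatter), the second is an at least 3.8-fold higher number from compound 1 to compound 3 (0.58 log units; beyond the scatter), and the third is an at least 1.6-fold higher number from compound 2 to compound 3 (0.22 log units; that floor lies within the scatter). These steps show how far a change elsewhere moved the number in these three compounds, but they give no direction for the new change. With no direction to go on, no step beyond the scatter is expected, and the uncertainty stays wide in both directions. The expected size of the change is a 1.2-fold lower number from compound 2 to compound 4 (0.07 log units; within the scatter). For compound 4 the estimated value in this assay is 5000 nM, with an expected range from 1500 nM to 14000 nM.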

Compound 4, concentration for 50% growth inhibition: 5120 nM
Compound 4: the middle estimate sits 1.0-fold (0.01 log units) below what was measured, and the stated range covers the measured number.
By their numbers in this assay, from the lowest: compounds 1, 4 and 2 (each within the scatter of the next, the first and the last beyond it). At a limit, above all of these: compound 3.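

Within the data shown here, compound 4 gives the first reading at the oxygen on the aromatic ring, since every earlier step changed the saturated chain carbon bound to an oxygen next to a carbonyl group. In this assay, turning 3-methoxyphenyl into 3-hydroxyphenyl gives a 1.2-fold lower number from compound 2 to compound 4 (0.06 log units; within the scatter), so in this one pair the methyl on that oxygen can be replaced by hydrogen with no change that stands out from the scatter, whereas the earlier 2.3-fold higher number from compound 1 to compound 2 (0.36 log units; beyond the scatter) at the other place is printed as beyond it. Nothing measured here bears on what lies behind this result.

On these data alone, a single pair cannot show whether this place tolerates change in general, so it remains open whether a longer chain on that oxygen, or an amine in place of the hydroxy, would leave the number where it is. As far as these compounds go, it is also open whether the same swap from methoxy to hydroxy would read alike on compound 1, which differs from compound 2 at the other place.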